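Swapping Two Aryl Methyls for One Ethyl

This account rests on a few compounds, and the source may have more. Where it says the series, first, only, none or still open, it means among the compounds named here.

compound 1 `Cc1ccc(C)c(-c2nc(CN3CCC(C(=O)NCCCN4C[C@H](C)C[C@H](C)C4)CC3)c(C)o2)c1`: 0.5 h
compound 2 `Cc1ccccc1-c1nc(CN2CCC(C(=O)NCCCN3CCC(C)CC3)CC2)c(C)o1`: > 0.5 h
compound 3 `Cc1ccccc1-c1nc(CN2CCC(C(=O)NCCCCN3C[C@H](C)C[C@H](C)C3)CC2)c(C)o1`: 0.2 h

Three compounds sharing one core were tested in an ADME assay on microsomes from liver (Rattus norvegicus) for metabolic stability, read by LC-MS, using NADPH, at 37 degrees C; on this read-out lower numbers stand for a shorter-lived compound and higher numbers for a longer-lived compound. Compound 1 gives 0.5 h, the higher of the two numbers; compound 3 gives 0.2 h. For compound 2 the read-out is only a limit of the assay, > 0.5 h; (the limit of > 0.5 h in this assay, at which 1 of the 3 values shown sits). Among the measured compounds shown here, the single measured step, an at least 2.5-fold lower number from compound 2 to compound 3 (0.39 log units; beyond the scatter), alters the ring at the far end of the chain, not the aromatic group on the core. Compound 4 `CCc1ccccc1-c1nc(CN2CCC(C(=O)NCCCN3C[C@H](C)C[C@H](C)C3)CC2)c(C)o1` differs from compound 1 elsewhere: 2-ethylphenyl in place of 2,5-dimethylphenyl on an aromatic carbon. For the measured compounds named here, no measured step touches this position, so no shift beyond the scatter is expected; the estimated step of no change at the digits printed from compound 1 to compound 4 (within the scatter) amounts to none. Compound 4 is therefore expected to give 0.5 h, between 0.25 h and 1 h.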

Compound 4, half-life: 0.283 h
The estimate for compound 4 lay 1.8-fold (0.25 log units) above the measured number; low and high end bracket the measured number.
By their numbers in this assay, from the lowest: compounds 3, 4 and 1 (each within the scatter of the next, the first and the last beyond it).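

Among the compounds shown here, this is the first measured change to the aromatic group on the shared core. In this assay, 2-ethylphenyl in place of 2,5-dimethylphenyl gives a 1.8-fold lower number from compound 1 to compound 4 (0.25 log units; within the scatter), so at this position the two groups cannot be told apart on this read-out. Nothing shown speaks to the reason for this result.

From the compounds shown here alone, how a phenyl ring carrying a methoxy group or a chlorine atom would read at this position stays open. So does whether the same swap would give a similar result with the other chain ends of compound 2 and compound 3.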